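Thiazole acetic acids: hydroxypyridinyl in place of sulfamoylphenyl

This account rests on a few compounds, and the source may have more. Where it says the series, first, only, none or still open, it means among the compounds named here.

Two measured compounds share the core with a carboxymethyl group. Within the data shown here, compound 1 `O=C(O)Cc1sc(CS(=O)(=O)c2ccc(Cl)cc2)nc1-c1ccc(Cl)cc1` and compound 2 `NS(=O)(=O)c1ccc(-c2nc(C(c3ccc(F)cc3)c3ccc(F)cc3)sc2CC(=O)O)cc1` differ from each other in more than one place, so no single step between them is drawn. In an in vitro assay on HEK385-7 cells for displacement of a labelled ligand from prostaglandin D2 receptor 2 (Homo sapiens) (on this read-out higher numbers stand for weaker inhibition and lower numbers for stronger inhibition), compound 1 gives 1500 nM. In this assay compound 2 gives 1500 nM, level with compound 1 within the scatter of the read-out. Compound 3 `O=C(O)Cc1sc(C(c2ccc(F)cc2)c2ccc(F)cc2)nc1-c1ccnc(O)c1` differs from compound 2 in one place: 2-hydroxypyridin-4-yl in place of 4-sulfamoylphenyl on an aromatic carbon. The two measured compounds, despite their differing substituents, sit at the same level, which gives no ground to expect a large move from this change either. The step is expected to be small, leaning if anything toward weaker inhibition, as a 1.7-fold higher number from compound 2 to compound 3 (0.22 log units; within the scatter). Compound 3 is expected to give 2500 nM in this assay, with a range of 800 nM to 8000 nM.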

Compound 3, half-maximal inhibitory concentration: 68 nM
For compound 3 the middle estimate is 37-fold (1.57 log units) above the measured one; measured number below the stated range.
By their numbers in this assay, from the lowest: compound 3; then compounds 1 and 2 (each within the scatter of the next).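

In this assay, the aromatic carbon next to the ring nitrogen and next to the ring atom that bears a carboxymethyl group proves sensitive to its substituent: 2-hydroxypyridin-4-yl in place of 4-sulfamoylphenyl gives a 22-fold lower number from compound 2 to compound 3 (1.34 log units; beyond the scatter) on an otherwise unchanged structure. Compounds 1 and 2 differ in more than one place, so their matching values could not show this; the entering and leaving groups have the same counts of hydrogen-bond donors and acceptors, although the entering group has fewer heavy atoms. Nothing available accounts for the size of this step.

As far as these compounds go, it remains open which part of 2-hydroxypyridin-4-yl matters; plain pyridin-4-yl and 3-hydroxyphenyl at this position would separate the ring nitrogen from the oxygen. Also open, from the compounds shown here alone, is whether the same change carries over to the core of compound 1.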